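Methyl on the amine nitrogen of compound 2

The source may hold more compounds than are shown below. What is called first, only, known or untested is meant among the compounds shown, and "the series" means these compounds.

In a functional assay on HCT-8 cells (Homo sapiens) for antiproliferative activity, read by MTT assay, with a stated time of 48 h (a higher number here means a weaker inhibitor, a lower number a stronger inhibitor), compound 1 (`C=C(c1cc(OC)c(OC)c(OC)c1)c1ccc(OC)cc1NC(=O)CO`) gives 40 nM. Sharing the core of compound 1, compound 2 (`C=C(c1cc(OC)c(OC)c(OC)c1)c1ccc(OC)cc1NC(=O)CN`) gives 60 nM, so these two numbers lie within the usual scatter of each other. For the measured compounds named here, with only two measured values, there is little to show how widely this family of compounds can spread.

Compound 3 (`C=C(c1cc(OC)c(OC)c(OC)c1)c1ccc(OC)cc1NC(=O)CNC`) comes from compound 2 through one small edit: methyl in place of hydrogen on an amine nitrogen. Put simply, this is methyl in place of hydrogen on an amine nitrogen. Going by the values given here, the one measured step that bears on it puts amino in place of hydroxy on a saturated chain carbon bound to a carbonyl carbon: a 1.5-fold higher number from compound 1 to compound 2 (0.18 log units; within the scatter). Among the compounds with values here, that step stays within the scatter, and it is only indirect evidence, since no measured pair shows what adding a methyl does.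

No step beyond the scatter is therefore expected in this assay, and neither direction is clearly favoured. The estimated step is a 1.2-fold higher number from compound 2 to compound 3 (0.07 log units; within the scatter). For compound 3 the expected value is 70 nM, with an estimated range from 30 nM to 200 nM.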

Compound 3, half-maximal inhibitory concentration: 190 nM
Beside the measured number, compound 3's estimate is 2.7-fold (0.43 log units) below it; the measured number falls inside the stated range.
By their numbers in this assay, from the lowest: compounds 1 and 2 (each within the scatter of the next); then compound 3.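

In this assay, for the compounds shown here, the amine nitrogen proves sensitive to a very small edit: one methyl in place of hydrogen gives a 3.2-fold higher number from compound 2 to compound 3 (0.50 log units; beyond the scatter) and so produces the first step in this set that lies beyond the usual scatter. The earlier swap of hydroxy for amino stayed within the scatter, so the two end groups first seen on this chain gave no sign that a single added carbon could matter more. Measured against the hydroxy compound as well, methylamino gives a 4.8-fold higher number from compound 1 to compound 3 (0.68 log units; beyond the scatter) and makes compound 3 the weakest inhibitor of the three, but no measured evidence here accounts for the loss.

One methyl cannot show whether the number keeps rising as the nitrogen carries more carbon, and an ethylamino group or a dimethylamino group at this place would test that. Going by these compounds, it also remains open whether the effect is tied to the amine nitrogen, which a methoxy group in place of the hydroxy on the chain of compound 1 could help to answer.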